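An amide exchange and its expected clearance

This account rests on a few compounds, and the source may have more. Where it says the series, first, only, none or still open, it means among the compounds named here.

Compound 1 `O=C(N[C@H]1CN(S(=O)(=O)c2ccccc2)C[C@@H]1C(=O)N1C[C@H]2CCNC[C@H]21)c1cc(-c2ccccc2Cl)on1`: 4.7 uL/min
Compound 2 `CN(C(=O)c1cc(-c2ccccc2Cl)on1)[C@H]1CN(S(=O)(=O)c2ccccc2)C[C@@H]1C(=O)N[C@H]1CCCNC1`: 12 uL/min

Of the compounds shown here, two have so far been measured in an ADME assay on cells (Hepatocyte, Rattus norvegicus) for metabolic stability; a lower number here means slower removal, a higher number faster removal of the compound. Compound 1 gives 4.7 uL/min, the lowest of the two numbers, and compound 2 gives 12 uL/min, a value beyond the scatter above that of compound 1. Among the measured compounds shown here, no step between two measured compounds that differ in a single place is available, so the measured pair gives only a rough sense of where neighbouring structures fall in this assay.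

Compound 3 `CC(=O)N1CCC[C@H](NC(=O)[C@H]2CN(S(=O)(=O)c3ccccc3)C[C@@H]2NC(=O)c2cc(-c3ccccc3Cl)on2)C1` has not yet been measured. It differs from compound 1 in one place: a group of 10 heavy atoms (7 carbon, 2 nitrogen, 1 oxygen; one six-membered non-aromatic ring with 1 hetero atom) in place of a group of 8 heavy atoms (6 carbon, 2 nitrogen; one four-membered non-aromatic ring with 1 hetero atom, one six-membered non-aromatic ring with 1 hetero atom), on a carbonyl carbon. For the measured compounds named here, the only other number, that of compound 2 at 12 uL/min, lies above compound 1, and this is the sole hint at hand for what a change at this carbonyl carbon may bring. The step from compound 1 to compound 3 is expected to be modest and upward, a 1.7-fold higher number from compound 1 to compound 3 (0.23 log units; within the scatter), most likely within the scatter. Compound 3 is therefore estimated at 8 uL/min, with a range of 3 uL/min to 20 uL/min.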

Compound 3, intrinsic clearance in a liver preparation (reported as CLH), per the amount of preparation that the assay uses: 196 uL/min
Estimate against measurement, compound 3: 25-fold (1.39 log units) below; measured number above the stated range.
By their numbers in this assay, from the lowest: compound 1; then compound 2; then compound 3.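

In this assay, the exchange on this carbonyl carbon, whose other neighbour is a saturated ring carbon, brings a 42-fold higher number from compound 1 to compound 3 (1.62 log units; beyond the scatter), a large step beyond the scatter, and so this place is far from indifferent to the group it carries. Among the compounds shown here, the earlier numbers could not show this: compound 1 and compound 2 differ in more than one place, and this step is the first to isolate a single change with the rest of the core of compound 1 kept. Nothing at hand gives a reason for the size of the step.

This one exchange alters several features together: the group with the four-membered ring leaves, and a group with a single six-membered non-aromatic ring and a double bond outside aromatic rings enters, and the compounds shown do not separate which of these goes with the higher number. Also open, going by these compounds, is how the number would respond, with the rest of compound 3 kept, to a carboxylic acid or a longer chain on that six-membered ring.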